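A few compounds are considered here, and "the series" means these few. Any claim that something is new, unique, unknown or untested is made for them only; others in the source may bear on it.

Compound 1 `COc1cc2ncnc(Nc3ccc(B(O)O)cc3)c2cc1OC`: 49%
Compound 2 `COc1cc2ncnc(Nc3ccc(C(=O)O)cc3)c2cc1OC`: "not active" (no number reported)
Compound 3 `COc1cc2ncnc(Nc3ccc(N)cc3)c2cc1OC`: "not active" (no number reported)

In an assay on isolated protein for inhibition of vascular endothelial growth factor receptor 1 (Homo sapiens), read by ELISA, with a stated time of 20 min, tested at 1 uM (a higher number here means more inhibition at the concentration tested (going by the name of the read-out), a lower number less inhibition), compound 3 is reported as "not active" (no number reported) without any number attached. Compound 2 stands in the same position, being reported as "not active" (no number reported) in this assay. Only compound 1 carries a figure, giving 49% in this assay, so the three measured compounds split into one with a number and two without, and no comparison of size can be drawn between compound 3 and either of the others.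

The compound not yet measured is compound 4 `COc1cc2ncnc(Nc3ccc(C#N)cc3)c2cc1OC`. It differs from compound 3 in a single place: cyano in place of amino on an aromatic carbon. Among the compounds with values here, since compound 3 has no number, no step can be computed for this change, and nothing among the measured compounds shows what cyano in this position does. The expectation in this assay is therefore a small step at most, perhaps from no reported number to a low one, not a move beyond the scatter into the region where compound 1 sits. For compound 4 the estimated inhibition in this assay is 15%, expected to fall between 0% and 45%.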

Compound 4, a percentage reported as inhibition, at one concentration (the size of the read-out at that concentration, not a potency): "not active" (no number reported)
Compound 4 has no reported number here, so the estimate cannot be set against anything.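

In this assay compound 4, like compound 3, carries no number, so no step can be read between them. Nothing available bears on this result. As far as these compounds go, whether compound 2, compound 3 and compound 4 differ among themselves, and how far each lies from compound 1, stays open.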